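This account rests on a few compounds, and the source may have more. Where it says the series, first, only, none or still open, it means among the compounds named here.

In a functional assay on HeLa cells (Homo sapiens) for cytotoxicity, read by MTT assay (on this read-out lower numbers stand for stronger inhibition and higher numbers for weaker inhibition), compound 1 (`CC(C)=CC[C@@H](OCC(C)O)C1=CC(=O)c2c(O)ccc(O)c2C1=O`) gives 24700 nM and compound 2 (`CCC(C)(O)CC(=O)O[C@H](CC=C(C)C)C1=CC(=O)c2c(O)ccc(O)c2C1=O`) gives 25200 nM, with no difference beyond the scatter, while compound 3 (`CC(C)=CC[C@@H](OC(=O)C1CCCOC1)C1=CC(=O)c2c(O)ccc(O)c2C1=O`) gives 60500 nM and so stands highest of the three. Compound 4 (`CCC(CO[C@H](CC=C(C)C)C1=CC(=O)c2c(O)ccc(O)c2C1=O)OC`) differs from compound 3 by a single change, 2-methoxybutyl in place of (oxan-3-yl)carbonyl on an oxygen on a saturated carbon. The nearest measured guide is the modest step of a 2.4-fold higher number from compound 1 to compound 3 (0.39 log units; beyond the scatter) on that same oxygen, where (oxan-3-yl)carbonyl replaced 2-hydroxypropyl. A similar modest step, a 2.4-fold higher number from compound 2 to compound 3 (0.38 log units; beyond the scatter) on a carbonyl carbon, came with oxan-3-yl in place of 2-hydroxy-2-methylbutyl. The step of a 1.0-fold higher number from compound 1 to compound 2 (0.01 log units; within the scatter) stayed within the scatter, and compound 2 therefore goes against any reading that a carbonyl alone raises the number. For the measured compounds named here, compound 4 gives up the oxan-3-yl ring, so a return toward compound 1 at 24700 nM is expected, although no measured compound carries 2-methoxybutyl. The expected step is a 2.0-fold lower number from compound 3 to compound 4 (0.30 log units; within the scatter) toward a lower number, of about the same modest size. Compound 4 is estimated at 30000 nM with an expected range of 13000 nM to 65000 nM in this read-out.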

Compound 4, half-maximal inhibitory concentration: 63500 nM
The estimate for compound 4 lay 2.1-fold (0.33 log units) below the measured number; low and high end bracket the measured number.
By their numbers in this assay, from the lowest: compounds 1 and 2 (each within the scatter of the next); then compounds 3 and 4 (each within the scatter of the next).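

In this assay the step of a 1.0-fold higher number from compound 3 to compound 4 (0.02 log units; within the scatter) shows that this oxygen on a saturated carbon accepts 2-methoxybutyl in place of (oxan-3-yl)carbonyl without a change beyond the scatter, so the higher number of compound 3 does not depend on keeping that ring or that carbonyl. The steps of a 2.5-fold higher number from compound 2 to compound 4 (0.40 log units; beyond the scatter) and a 2.6-fold higher number from compound 1 to compound 4 (0.41 log units; beyond the scatter) place compound 4 with compound 3 and show that removing the carbonyl does not by itself bring the number back toward compound 1. Among these four compounds, the two lower numbers belong to compound 1 and compound 2, which carry a hydroxy group on the side chain, and the two higher numbers belong to compound 3 and compound 4, which do not; no compound shown goes against this, but four compounds are a narrow basis.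

The step from compound 1 to compound 4 changes both the chain length and the hydroxy group to methoxy, so the two changes cannot be told apart. On these data alone, a 2-hydroxybutyl chain on this oxygen would separate them, while an amine or a carboxylic acid at the same place remains open. The data shown offer no evidence on why these numbers fall as they do.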